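This account rests on a few compounds, and the source may have more. Where it says the series, first, only, none or still open, it means among the compounds named here.

In an ADME assay on microsomes from liver (Mus musculus) for metabolic stability, with a stated time of 10 min (on this read-out higher numbers stand for a more stable compound and lower numbers for a less stable compound), compound 3 `COC(=O)[C@H]1CC[C@H](C(=O)N2CC[C@](c3ccc(C(F)(C(F)(F)F)C(F)(F)F)cc3)(S(=O)(=O)c3ccc(F)cc3)C2)CC1` offers no starting number, since its entry reads "not determined" (no result reported) and nothing more. Compound 4 `O=C([C@H]1CC[C@H](CO)CC1)N1CC[C@](c2ccc(C(F)(C(F)(F)F)C(F)(F)F)cc2)(S(=O)(=O)c2ccc(F)cc2)C1` differs from compound 3 by hydroxymethyl in place of methoxycarbonyl on a saturated ring carbon with hydroxymethyl in place of methoxycarbonyl on a saturated ring carbon. Two relatives with the same core do have numbers in this assay because compound 1 `C[C@]1(C(=O)O)CC[C@H](C(=O)N2CC[C@](c3ccc(C(F)(C(F)(F)F)C(F)(F)F)cc3)(S(=O)(=O)c3ccc(F)cc3)C2)CC1` gives 93% and compound 2 `O=C(O)C12CCC(C(=O)N3CC[C@](c4ccc(C(F)(C(F)(F)F)C(F)(F)F)cc4)(S(=O)(=O)c4ccc(F)cc4)C3)(CC1)OC2` gives 94% there. Among the compounds with values here, the only measured step is a number 1 percentage points higher from compound 1 to compound 2 (within the scatter) and neither compound carries methoxycarbonyl or hydroxymethyl, so it gives no size for this change. Within the data shown here, no step from compound 3 can be stated, and compound 4 is simply expected near those two values or somewhat under them. Compound 4 is estimated at 82% within a range from 55% to 97% on this read-out.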

Compound 4, percent of the compound remaining: 63%
Estimate against measurement, compound 4: 19 percentage points above; low and high end bracket the measured number.
By their numbers in this assay, from the lowest: compound 4; then compounds 1 and 2 (each within the scatter of the next).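

Swapping only the group on the carbonyl carbon can move this read-out well beyond the scatter: this assay shows a number 31 percentage points lower from compound 2 to compound 4 (beyond the scatter) and a number 30 percentage points lower from compound 1 to compound 4 (beyond the scatter). Within the data shown here, the single earlier step stayed within the scatter, so this position is more sensitive than compounds 1 and 2 alone suggested. Nothing available here explains the drop.

The step from compound 3 cannot be read, so the swap of methoxycarbonyl for hydroxymethyl has no size of its own. As far as these compounds go, whether a ring carrying an amine or a longer chain such as hydroxyethyl would sit nearer compound 4 or compound 1 stays open.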